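Adding a Methyl to a Compound Seen Only at Its Limit

This account rests on a few compounds, and the source may have more. Where it says the series, first, only, none or still open, it means among the compounds named here.

Compound 1 `Cc1cc(C(=O)O)ccc1CN1CCC[C@H](OC(c2cc(Cl)cc(Cl)c2)C(C)O)[C@@H]1c1ccccc1` and compound 2 `Cc1cc(C(=O)O)ccc1CN1CCC[C@H](O[C@H](CO)c2ccnc(Cl)c2)[C@@H]1c1ccccc1` share one core and were examined in an assay on isolated protein for activation of cGMP-dependent protein kinase 1 (Homo sapiens), read by ADP-Glo, with stated times of 30 min and 2 h; on this read-out higher numbers stand for an effect only at larger amounts of compound and lower numbers for an effect already at smaller amounts. In this assay compound 1 gives > 196000 nM, which is a limit of the assay rather than a number. Compound 2 gives > 200000 nM in this assay, likewise a limit. Going by the values given here, the step that the two limits leave unreadable from compound 1 to compound 2 is therefore left unreadable by the two limits, and no sized step is available among the measured compounds.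

Compound 3 `Cc1cc(C(=O)O)ccc1CN1CCC[C@H](OC(c2cc(Cl)cc(Cl)c2)C(C)(C)O)[C@@H]1c1ccccc1` differs from compound 1 by methyl in place of hydrogen on a saturated chain carbon bound to an oxygen on a saturated carbon and two saturated chain carbons. Among the compounds with values here, no measured step bears directly on this change, so the expectation rests on where compound 1 stands at its limit. The step that the limit leaves unreadable from compound 1 to compound 3 is expected to show nothing beyond the scatter. Compound 3 is accordingly estimated at 200000 nM, within a range from 50000 nM to 600000 nM, most probably reported once more as a limit.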

Compound 3, half-maximal effective concentration: 121000 nM
The estimate for compound 3 lay 1.7-fold (0.22 log units) above the measured number; the measured number falls inside the stated range.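

In this assay, going by these compounds alone, compound 3 gives 121000 nM as the first actual number at this position. The earlier compounds shown here offered only limits and their step cannot be read. The change from 1-hydroxyethyl to 1-hydroxy-1-methylethyl amounts to an at least 1.6-fold lower number from compound 1 to compound 3 (0.20 log units; that floor lies within the scatter) and so shows that a methyl in place of hydrogen on this carbon is compatible with a measurable value, without establishing a change beyond the scatter. From the compounds shown here alone, the true size of the step stays open because compound 1 is held only as a limit: the limit of > 196000 nM in this assay, at which 1 of the 3 values shown sits.

The compounds shown leave open whether an ethyl group or a cyclopropyl ring on this carbon would lower the number further. They also leave open whether an amine in place of the hydroxyl would keep a readable value.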